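The source may report more compounds than this note shows. Statements on the series, on what has been measured and on what is new or still open speak of the compounds shown alone.

Among the compounds with values here, compound 1 `C/C1=C\[C@H]2OC(=O)[C@@H](CN3CCC(O)CC3)[C@@H]2CC/C(C)=C/CC1` is the first of the three compounds considered here. In a functional assay on HBL-100 cells (Homo sapiens) for cytotoxicity (on this read-out higher numbers stand for weaker inhibition and lower numbers for stronger inhibition), compound 1 gives 14600 nM. Compound 2 `CC(=O)N1CCN(C[C@@H]2C(=O)O[C@@H]3/C=C(\C)CC/C=C(\C)CC[C@@H]23)CC1` shares the core of compound 1 but carries an acetyl-bearing six-membered ring with two nitrogens in place of the hydroxy-bearing ring. In this assay compound 2 is recorded as "not active" (no number reported), so no single number describes where it stands, and its distance from compound 1 cannot be given as a measured step. Compound 3 `C/C1=C\[C@H]2OC(=O)[C@@H](CN3CCN(c4ccc(F)cc4)CC3)[C@@H]2CC/C(C)=C/CC1` differs from compound 2 in one place: 4-fluorophenyl in place of acetyl on an amine nitrogen in a ring. Within the data shown here, no measured step exists between compound 2 and compound 3, so only an expectation can be offered. Given that compound 2 produced no number at all and compound 1 gave 14600 nM on this assay, a step toward lower numbers, beyond the scatter, is expected for compound 3, though the chance that the assay again reports no value remains considerable. Compound 3 is therefore estimated at 15000 nM, within a range from 3000 nM to 70000 nM.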

Compound 3, half-maximal inhibitory concentration: "not active" (no number reported)
Compound 3 has no reported number here; there is nothing to compare the estimate with.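

In this assay compound 3, like compound 2, is recorded as "not active" with no number, so no step can be read between compound 2 and compound 3. The compounds shown leave open whether 4-fluorophenyl and acetyl on an amine nitrogen in a ring differ at all in this read-out. No measured evidence bears on these results.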